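Aryl amide replacement in a glycinamide series

The source may hold more compounds than are shown below. What is called first, only, known or untested is meant among the compounds shown, and "the series" means these compounds.

Measured compounds:
compound 1 `CN1CCC(C(=O)N(CC(=O)Nc2cc(F)cc(F)c2)C2CCCCC2)CC1` gives > 25100 nM in an assay on HEK293 cells for inhibition of sodium- and chloride-dependent glycine transporter 1 (Homo sapiens), read by scintillation proximity assay; a lower number here means a stronger inhibitor, a higher number a weaker inhibitor; this value is a limit of the assay.
compound 2 `O=C(CN(C(=O)c1cccnc1)C1CCCCC1)Nc1cc(F)cc(F)c1` gives > 25100 nM in this assay; this value is a limit of the assay.
compound 3 `Cn1ccc(C(=O)N(CC(=O)Nc2cc(F)cc(F)c2)C2CCCCC2)n1` gives > 25100 nM in this assay; this value is a limit of the assay.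

Within the data shown here, compound 3 sits at the limit of > 25100 nM in this assay, at which 3 of the 3 values shown sit, and the two other measured compounds sit there as well, so no measured compound in this set has a readable value. The steps among them, a step that the two limits leave unreadable from compound 1 to compound 2, a step that the two limits leave unreadable from compound 1 to compound 3 and a step that the two limits leave unreadable from compound 2 to compound 3, cannot be read and give no size to work from.

Compound 4 `O=C(CN(C(=O)c1cccc(Cl)c1)C1CCCCC1)Nc1cc(F)cc(F)c1` differs from compound 3 by 3-chlorophenyl in place of 1-methyl-1H-pyrazol-3-yl on a carbonyl carbon. Among the measured compounds shown here, no measured step puts a number on this kind of change; all the measured steps show is that exchanging one group on the carbonyl carbon for another left the value at the limit. The outcome in this assay is therefore open: either a limit again, or a step to a measurable value. The step from compound 3 to compound 4 is estimated as an at least 5.0-fold lower number from compound 3 to compound 4 (0.70 log units; beyond the scatter). Compound 4 is expected at 5000 nM, with a range from 500 nM to 30000 nM.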

Compound 4, half-maximal inhibitory concentration in the sodium- and chloride-dependent glycine transporter 1 assay: 1580 nM
The estimate for compound 4 lay 3.2-fold (0.50 log units) above the measured number, and the stated range covers the measured number.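

Among these compounds, in the sodium- and chloride-dependent glycine transporter 1 assay, compound 4, with 3-chlorophenyl on the carbonyl carbon, gives the first readable value in the set (1580 nM), with an at least 15-fold lower number from compound 3 to compound 4 (1.20 log units; beyond the scatter), an at least 15-fold lower number from compound 2 to compound 4 (1.20 log units; beyond the scatter) and an at least 15-fold lower number from compound 1 to compound 4 (1.20 log units; beyond the scatter). Each of these sizes is only a bound, and compound 4 alone stands off the shared limit: the limit of > 25100 nM in the sodium- and chloride-dependent glycine transporter 1 assay, at which 3 of the 4 values shown sit. The steps among compound 1, compound 2 and compound 3 cannot be read, so only compound 4 shows that a change at this position can move the value, here with a six-membered aromatic ring of carbon only and 0 hydrogen-bond acceptors entering.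

From the compounds shown here alone, whether the chlorine or the carbon-only ring carries the step stays open, and plain phenyl, 3-methoxyphenyl or 3-cyanophenyl would separate the two. In a physicochemical assay for lipophilicity (a higher number here means a more lipophilic compound, a lower number a more polar compound), compound 3 gives 3, compound 4 gives "not determined" (no result reported) and no comparison between them can be drawn.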